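This account rests on a few compounds, and the source may have more. Where it says the series, first, only, none or still open, it means among the compounds named here.

Compound 1 `Nc1sc(-c2ccccc2)cc1C(=O)c1ccccc1` gives 12% in an assay on CHO cells for positive allosteric modulation of adenosine receptor A1 (Homo sapiens), read by ERK phosphorylation, tested at 3 uM; a lower number here means a stronger effect, a higher number a weaker effect of the compound at the concentration tested. Compound 2 `Nc1sc(-c2cncnc2)cc1C(=O)c1ccccc1` differs from compound 1 by pyrimidin-5-yl in place of phenyl on an aromatic carbon, and in this assay compound 2 gives 18%; the step is a number 6 percentage points higher from compound 1 to compound 2 (within the scatter). Compound 3 `Nc1sc(-c2ccccc2)cc1C(=O)c1ccc(Cl)cc1` has a different core from compound 1, the difference being (chloro in place of hydrogen on an aromatic carbon); in this assay compound 3 gives 46%, and the step is a number 34 percentage points higher from compound 1 to compound 3 (beyond the scatter). Of the three measured compounds, compound 3 stands highest, and its number lies above that of compound 2 as well as that of compound 1.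

Compound 4 `Nc1sc(-c2cncnc2)cc1C(=O)c1ccc(Cl)cc1` has not yet been measured. It differs from compound 3 by pyrimidin-5-yl in place of phenyl on an aromatic carbon, the same kind of change as that from compound 1 to compound 2, made here two ring bonds from the ring atom that bears a group of 9 heavy atoms rather than 8. Since that earlier change gave a number 6 percentage points higher from compound 1 to compound 2 (within the scatter), the same kind of change from compound 3 is expected to give a number 6 percentage points higher from compound 3 to compound 4 (within the scatter). Compound 4 is therefore estimated at 52%, with a likely range from 38% to 66%.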

Compound 4, a percentage reported as activity, at one concentration (the size of the read-out at that concentration, not a potency): 7%
For compound 4 the middle estimate is 45 percentage points above the measured one, and the stated range ends above it.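

In this assay, pyrimidin-5-yl in place of phenyl did not carry over from one core to the other: on the core of compound 3, which bears the chloro group, the change gave a number 39 percentage points lower from compound 3 to compound 4 (beyond the scatter), and the two steps differ: the same change on two cores in this assay, a number 6 percentage points higher (within the scatter) from compound 1 to compound 2 and a number 39 percentage points lower (beyond the scatter) from compound 3 to compound 4, 45 percentage points apart, beyond the scatter of two such steps The chloro group shows the same dependence, since with pyrimidin-5-yl present it gave a number 11 percentage points lower from compound 2 to compound 4 (beyond the scatter), opposite in direction to its step on the core of compound 1: the same change on two cores in this assay, a number 34 percentage points higher (beyond the scatter) from compound 1 to compound 3 and a number 11 percentage points lower (beyond the scatter) from compound 2 to compound 4, 45 percentage points apart, beyond the scatter of two such steps These four compounds thus show that the two changes do not add and that the effect of each depends on the other, but they rest on a single pair of steps for each change and do not show why this happens or whether it extends to other groups.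

The compounds shown leave open whether a pyridine ring in place of pyrimidin-5-yl would follow the same course. On these data alone, it also remains open whether a fluoro or methoxy group in place of chloro would reverse the step in the same way.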